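One Carbon Longer: From Compound 2 to Compound 3

This account rests on a few compounds, and the source may have more. Where it says the series, first, only, none or still open, it means among the compounds named here.

Of the compounds shown here, two sharing one core have been measured in an ADME assay on isolated protein for inhibition of Dihydrofolate reductase (Homo sapiens), using NADPH; a higher number here means a weaker inhibitor, a lower number a stronger inhibitor. Compound 1, `Nc1nc(N)c2nc(Nc3cccc4ccccc34)ccc2n1`, gives 1100 nM. Compound 2, `CN(c1ccccc1)c1ccc2nc(N)nc(N)c2n1`, gives 942 nM. In this assay compound 2 has the lowest of the two numbers, and its nearest neighbour is compound 1, whose number lies within the scatter of it, so the two cannot be told apart on these data.

Compound 3, `CCN(c1ccccc1)c1ccc2nc(N)nc(N)c2n1`, has not yet been measured. It differs from compound 2 by methyl in place of hydrogen on a saturated chain carbon bound to a nitrogen on an aromatic ring; viewed one bond further out, the change reads methyl to ethyl. Going by the values given here, no pair of measured compounds shows what such a step does here, so the expectation rests on the modest size of the change alone, a small addition to a chain that already exists. The step of a 1.0-fold higher number from compound 2 to compound 3 (0.00 log units; within the scatter) is expected to be small, in no clear direction, and probably not beyond the scatter. Compound 3 is therefore estimated at 950 nM, with a range from 400 nM to 2300 nM.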

Compound 3, half-maximal inhibitory concentration: 1570 nM
Beside the measured number, compound 3's estimate is 1.7-fold (0.22 log units) below it; the measured number falls inside the stated range.
By their numbers in this assay, from the lowest: compounds 2, 1 and 3 (each within the scatter of the next).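

In this assay, going by these compounds alone, the first step that can be read at this position, methyl in place of hydrogen on a saturated chain carbon bound to a nitrogen on an aromatic ring, is a 1.7-fold higher number from compound 2 to compound 3 (0.22 log units; within the scatter). Seen one bond further out, this is a change from methyl to ethyl, and on these data the two groups cannot be told apart, so the position accepts the slightly longer chain without a shift that stands clear of ordinary repeat-to-repeat variation. No accompanying measurement helps to explain this step, so the size of the step is all that can be reported.

On these data alone, a single step within the scatter cannot show a trend, so it remains open whether growing the chain further, to propyl or butyl, would eventually produce a real difference in either direction. As far as these compounds go, it is also open whether a chain ending in an amine or a carboxylic acid, or a cyclopropyl group at the same place, would separate clearly from methyl and ethyl.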